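Fluoro Substitution and Cytotoxicity in a Small Set

A few compounds are considered here, and "the series" means these few. Any claim that something is new, unique, unknown or untested is made for them only; others in the source may bear on it.

The measured compounds are as follows. Compound 1, `N/C(=N\NC(=S)N1CCCCCC1)c1ccccn1`, gives 2600 nM in a functional assay on MCF7 cells (Homo sapiens) for cytotoxicity, read by MTT assay, with a stated time of 72 h; on this read-out higher numbers stand for weaker inhibition and lower numbers for stronger inhibition. Compound 2, `N/C(=N\NC(=S)N1CCSCC1)c1ccccn1`, gives 8800 nM in this assay. Compound 3, `N/C(=N\NC(=S)N1CCSCC1)c1ccc(F)cn1`, gives 21400 nM in this assay.

Compound 1 has the lowest number of the three, and its steps to compound 2 and to compound 3 both lie beyond the scatter of the measurement. How the core of compound 1 differs from the core of compound 2 is not broken down here.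

One structural change is seen within the measured set. Compound 3 carries fluoro in place of hydrogen on an aromatic carbon relative to compound 2, and the step in this assay is a 2.4-fold higher number from compound 2 to compound 3 (0.39 log units; beyond the scatter).

Compound 4, `N/C(=N\NC(=S)N1CCCCCC1)c1ccc(F)cn1`, is not yet measured. It carries fluoro in place of hydrogen on an aromatic carbon relative to compound 1, the same change that separates compound 2 and compound 3. Within the data shown here, the expectation for compound 4 therefore rests on that single measured step, because a 2.4-fold higher number from compound 2 to compound 3 (0.39 log units; beyond the scatter) is the only guide available, and it rests on the core of compound 1 rather than that of compound 2. In this assay the step from compound 1 to compound 4 is expected to be a 2.4-fold higher number from compound 1 to compound 4 (0.38 log units; beyond the scatter). Compound 4 is accordingly estimated at 6200 nM in this assay, with a range from 2600 nM to 15000 nM.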

Compound 4, half-maximal inhibitory concentration: 21100 nM
Estimate against measurement, compound 4: 3.4-fold (0.53 log units) below; the whole stated range lies below it.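

In this assay, fluoro in place of hydrogen on an aromatic carbon gives a higher number on the core of compound 1 as well, the step being an 8.1-fold higher number from compound 1 to compound 4 (0.91 log units; beyond the scatter). Among these compounds, the direction of the change therefore carries from one core to the other in this pair of steps, but its size does not, and the two steps differ by more than the scatter allows: the same change on two cores in this assay, a 2.4-fold higher number (0.39 log units; beyond the scatter) from compound 2 to compound 3 and an 8.1-fold higher number (0.91 log units; beyond the scatter) from compound 1 to compound 4, 3.3-fold (0.52 log units) apart, beyond the scatter of two such steps These data show that the size of the fluoro step depends on the core it sits on in this small set, but they do not show why, and with only two cores they give no rule for predicting the step on a further core.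

The compounds shown leave open whether another group on the same aromatic carbon, such as chloro, methoxy or an amine, would follow the direction seen with fluoro. They also leave open whether the dependence on the core would persist with such groups, and whether a carboxylic acid or a longer chain at that place would bring the number down rather than up.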